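Removing tert-butoxycarbonyl from compound 2

A few compounds are considered here, and "the series" means these few. Any claim that something is new, unique, unknown or untested is made for them only; others in the source may bear on it.

In an ADME assay on Vero cells (Chlorocebus sabaeus) for cytotoxicity, with a stated time of 48 h (a lower number here means that less compound is tolerated, a higher number that more compound is tolerated), compound 2 (`CCC(CC)O[C@@H]1C=C(C(=O)Nc2ccccc2OC)C[C@H](NC(=O)OC(C)(C)C)[C@H]1NC(C)=O`) gives 753000 nM and sits level with compound 3 (`CCC(CC)O[C@@H]1C=C(C(=O)Nc2ccccc2)C[C@H](NC(=O)OC(C)(C)C)[C@H]1NC(C)=O`) at 752000 nM on this scale, while compound 1 (`CCC(CC)O[C@@H]1C=C(C(=O)Nc2ccccc2)C[C@H](N)[C@H]1NC(C)=O`) lies lower at 150000 nM among the three. Compound 4 (`CCC(CC)O[C@@H]1C=C(C(=O)Nc2ccccc2OC)C[C@H](N)[C@H]1NC(C)=O`) has hydrogen in place of tert-butoxycarbonyl on an amine nitrogen. The closest measured evidence is the same change read in reverse (a 5.0-fold higher number from compound 1 to compound 3 (0.70 log units; beyond the scatter)), which lies beyond the scatter. Hydrogen in place of methoxy made no difference beyond the scatter (a 1.0-fold lower number from compound 2 to compound 3 (0.00 log units; within the scatter)), so a step of similar size towards a lower number is expected here (a 5.0-fold lower number from compound 2 to compound 4 (0.70 log units; beyond the scatter)). Compound 4 is estimated at 150000 nM (range 75000 nM to 300000 nM).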

Compound 4, half-maximal cytotoxic concentration: 150000 nM
The estimate for compound 4 equals the measured number at the digits printed; the range from low to high includes it.
By their numbers in this assay, from the lowest: compounds 1 and 4 (each within the scatter of the next); then compounds 3 and 2 (each within the scatter of the next).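

In this assay removing tert-butoxycarbonyl from the amine nitrogen also lowers the number with methoxy present (a 5.0-fold lower number from compound 2 to compound 4 (0.70 log units; beyond the scatter)), so the step seen on the core of compound 1 recurs on a second core: (the same change on two cores in this assay, a 5.0-fold higher number (0.70 log units; beyond the scatter) from compound 1 to compound 3 and a 5.0-fold higher number (0.70 log units; beyond the scatter) from compound 4 to compound 2, 1.0-fold (0.00 log units) apart, within the scatter of two such steps). On the free amine, methoxy in place of hydrogen on an aromatic carbon again stays within the scatter (no change at the digits printed from compound 1 to compound 4 (within the scatter)), as it did with tert-butoxycarbonyl present: (the same change on two cores in this assay, a 1.0-fold lower number (0.00 log units; within the scatter) from compound 2 to compound 3 and no change at the digits printed (within the scatter) from compound 4 to compound 1, 1.0-fold (0.00 log units) apart, within the scatter of two such steps).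

Going by these compounds, whether an acetyl or a methyl group on this amine nitrogen gives a number like that of tert-butoxycarbonyl or that of hydrogen remains open. Also open, on these data alone, is whether a carboxylic acid or a chlorine in place of methoxy would stay within the scatter.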